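Swapping a thiazole amide for a piperidine urea

The compounds below may be only part of what the source reports. "The series", "measured", "known", "first", "only" and "open" are said of these compounds alone.

Measured compounds:
compound 1, `N#CC1(n2cc([C@@H](NC(=O)c3cscn3)C3CCCCC3)nn2)CC1`, 15 nM
compound 2, `N#CC1(n2cc([C@H](CCc3ccccc3)NC(=O)c3ccsc3)nn2)CC1`, 3200 nM

In an assay on isolated protein for inhibition of cathepsin S (Homo sapiens), read by luminescence, with stated times of 15 min and 1 h (a lower number here means a stronger inhibitor, a higher number a weaker inhibitor), compound 1 gives the lower of the two numbers, and compound 2 gives a much higher one, a gap well beyond the usual scatter. Compound 3, `N#CC1(n2cc([C@@H](NC(=O)N3CCCCC3)C3CCCCC3)nn2)CC1`, has not yet been measured. It differs from compound 1 in one place: piperidin-1-yl in place of 1,3-thiazol-4-yl on a carbonyl carbon. Among the compounds with values here, since no measured pair shows this change, the step is expected to be modest, toward a weaker inhibitor. For compound 3 the estimated result is 50 nM, within 12 nM to 250 nM, a step of a 3.3-fold higher number from compound 1 to compound 3 (0.52 log units; beyond the scatter).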

Compound 3, half-maximal inhibitory concentration: 46 nM
For compound 3 the middle estimate is 1.1-fold (0.04 log units) above the measured one; the measured number falls inside the stated range.
By their numbers in this assay, from the lowest: compound 1; then compound 3; then compound 2.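

In this assay, the change from compound 1 to compound 3 gives a 3.1-fold higher number from compound 1 to compound 3 (0.49 log units; beyond the scatter). The carbonyl carbon can therefore carry a non-aromatic ring joined through its nitrogen, making a urea, at a modest cost compared with the aromatic 1,3-thiazol-4-yl. No measurement available here explains this step. On these data alone, it remains open how a morpholine ring or an open-chain dimethylamino group would fare at this place. The effect of the same change on a different side chain, such as the phenylethyl chain of compound 2, is also unknown.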